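The source may report more compounds than this note shows. Statements on the series, on what has been measured and on what is new or still open speak of the compounds shown alone.

Compound 1 `O=C1NCCC12CCN(c1c(Cl)cncc1-c1cccs1)CC2` is the reference point. In a functional assay on MV4-11 cells (Homo sapiens) for inhibition, read by resazurin assay, with a stated time of 72 h (on this read-out lower numbers stand for stronger inhibition of growth and higher numbers for weaker inhibition of growth), compound 1 gives 480 nM, the lowest of the three numbers available. Compound 3 `Cc1csc(-c2cncc(Cl)c2N2CCC3(CCNC3=O)CC2)c1` gives 650 nM, and compound 2 `O=Cc1ccc(-c2cncc(Cl)c2N2CCC3(CCNC3=O)CC2)o1` gives 5190 nM. The step of a 1.4-fold higher number from compound 1 to compound 3 (0.13 log units; within the scatter) stays within the scatter, so compound 1 and compound 3 cannot be told apart, while the step of an 11-fold higher number from compound 1 to compound 2 (1.03 log units; beyond the scatter) is a clear loss and the step of an 8.0-fold lower number from compound 2 to compound 3 (0.90 log units; beyond the scatter) a clear recovery.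

Compound 4 `O=C1NCCC12CCN(c1c(Cl)cncc1-c1ccc(CN3CCCC3)s1)CC2` differs from compound 1 in one place: (pyrrolidin-1-yl)methyl in place of hydrogen on an aromatic carbon. The change sits on the same five-membered ring that carries the methyl of compound 3, and that addition cost little; the large loss came only when the whole ring was swapped for a 5-formylfuran-2-yl. Going by the values given here, no measured step adds a group like (pyrrolidin-1-yl)methyl, so the guidance is indirect. A step no larger than the scatter is expected in this assay, in either direction, as a 1.0-fold higher number from compound 1 to compound 4 (0.02 log units; within the scatter). Compound 4 is therefore estimated at 500 nM, within a range from 150 nM to 1700 nM.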

Compound 4, concentration for 50% growth inhibition: 3370 nM
Estimate against measurement, compound 4: 6.7-fold (0.83 log units) below; the whole stated range lies below it.
By their numbers in this assay, from the lowest: compounds 1 and 3 (each within the scatter of the next); then compounds 4 and 2 (each within the scatter of the next).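

Placing (pyrrolidin-1-yl)methyl on the aromatic carbon next to the ring sulfur gives a 7.0-fold higher number from compound 1 to compound 4 (0.85 log units; beyond the scatter) in this assay. This shows that the number can rise clearly while the thiophene ring stays in place, so a loss does not require swapping the whole ring, and the ring does not tolerate every addition, even though the methyl of compound 3 gave only a 1.4-fold higher number from compound 1 to compound 3 (0.13 log units; within the scatter). No measurement available here explains this step.

The compounds shown leave open whether the loss goes with the pyrrolidine ring, with its nitrogen, or with any group on this carbon. A plain methyl, a hydroxymethyl or a dimethylaminomethyl on this same carbon would help to tell these possibilities apart.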